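Oxime to Acetyl on Two Cores: One Predicted Step

The compounds below may be only part of what the source reports. "The series", "measured", "known", "first", "only" and "open" are said of these compounds alone.

Of the compounds shown here, three have been measured in a functional assay on the whole organism (strain albino) for inhibition, with Rattus norvegicus as the target, read by paw edema, with stated times of 30 min and 4 h, at a dose of 0.28 mmol/kg by the oral route; a lower number here means less inhibition, a higher number more inhibition at the dose given (going by the name of the read-out). Compound 1 `C=CCn1c(SCC(=O)Nc2ccc(C(C)=O)cc2)nnc1-c1ccc(OC)c(OC)c1` and compound 2 `C=CCn1c(SCC(=O)Nc2ccc(/C(C)=N/O)cc2)nnc1-c1ccc(OC)c(OC)c1` share one core and differ in a single group on an aromatic carbon: a group of 3 heavy atoms (2 carbon, 1 oxygen; no ring) in place of a group of 4 heavy atoms (2 carbon, 1 nitrogen, 1 oxygen; no ring), on an aromatic carbon. In this assay compound 2 gives 79%, and compound 1 gives 70%. This change made a step of a number 9 percentage points lower from compound 2 to compound 1 (within the scatter), so the two numbers cannot be told apart with confidence.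

Compound 3 `CCn1c(SCC(=O)Nc2ccc(/C(C)=N/O)cc2)nnc1-c1ccccc1` is built on a different core; how its core differs from that of compound 2 is not broken down here. In this assay compound 3 gives 77%, a number that lies within the usual scatter of both compound 2 and compound 1, so no order among the three can be claimed.

Compound 4 `CCn1c(SCC(=O)Nc2ccc(C(C)=O)cc2)nnc1-c1ccccc1` has not yet been measured. Within the data shown here, it is derived from compound 3 by exactly the same change as the one leading from compound 2 to compound 1: a group of 3 heavy atoms (2 carbon, 1 oxygen; no ring) in place of a group of 4 heavy atoms (2 carbon, 1 nitrogen, 1 oxygen; no ring), on an aromatic carbon. The place is described in the same words in both pairs, so this is the same change on another core. Because the earlier swap produced a number 9 percentage points lower from compound 2 to compound 1 (within the scatter), the step from compound 3 to compound 4 is expected to be a number 9 percentage points lower from compound 3 to compound 4 (within the scatter), a small drift rather than a real shift. Compound 4 is therefore estimated at 68% in this assay, expected to fall between 57% and 79%.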

Compound 4, a percentage reported as inhibition, in the whole organism at one dose (the size of the read-out at that dose, not a potency): 69%
The estimate for compound 4 lay 1 percentage points below the measured number; the measured number falls inside the stated range.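

Putting acetyl in place of the oxime group on the aromatic carbon of compound 3 gave, in this assay, a number 8 percentage points lower from compound 3 to compound 4 (within the scatter). Set beside the earlier swap, the change reads the same on both cores, so in these two pairs the core made no visible difference to its outcome: the same change on two cores in this assay, a number 9 percentage points lower (within the scatter) from compound 2 to compound 1 and a number 8 percentage points lower (within the scatter) from compound 3 to compound 4, 1 percentage points apart, within the scatter of two such steps. Among these compounds, this does not show that the swap itself has a real effect, since each step lies within the scatter and two close numbers would also arise if the oxime group and acetyl could not be told apart in this test at all; it also rests on only two cores and on one read-out at one dose, which gives the size of the response and not a potency.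

The compounds shown leave open whether a third core, carrying other groups on its ring nitrogen or on its aromatic ring, would follow the same course as these two. They also leave open what a carboxylic acid, an amine or a longer chain would give on that same aromatic carbon, where a step beyond the scatter might or might not appear.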